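Trading 3-ethynylphenyl for 3,4-dichlorophenyl on compound 1

The source may report more compounds than this note shows. Statements on the series, on what has been measured and on what is new or still open speak of the compounds shown alone.

Measured so far in a functional assay on MCF7 cells (Homo sapiens) for antiproliferative activity, read by MTT assay, with a stated time of 48 h (on this read-out lower numbers stand for stronger inhibition and higher numbers for weaker inhibition), for three compounds
compound 1 `C#Cc1cccc(Nc2ncnc3cc(NC(=O)/C=C/c4ccccc4)sc23)c1` gives 75600 nM
compound 2 `O=C(/C=C/c1ccccc1)Nc1cc2c(Nc3ccc(Cl)c(Cl)c3)ncnc2s1` gives 15300 nM
compound 3 `C#Cc1cccc(Nc2ncnc3sc(NC(=O)/C=C/c4ccccc4)cc23)c1` gives 38400 nM

Compound 1 and compound 3 lie within the scatter of each other, while compound 2 stands clearly lower than compound 1. Compound 4 `O=C(/C=C/c1ccccc1)Nc1cc2ncnc(Nc3ccc(Cl)c(Cl)c3)c2s1` keeps the core of compound 1 and exchanges one group (3,4-dichlorophenyl in place of 3-ethynylphenyl on a nitrogen on an aromatic ring), with 3,4-dichlorophenyl in place of 3-ethynylphenyl on a nitrogen on an aromatic ring. For the measured compounds named here, one measured step bears on this, the same exchange run backwards on a different core (a 2.5-fold higher number from compound 2 to compound 3 (0.40 log units; beyond the scatter)). Reversed, that modest step points to a lower number, though it may not carry over exactly. The expected change is therefore of similar size (a 2.5-fold lower number from compound 1 to compound 4 (0.40 log units; beyond the scatter)). Compound 4 is estimated at 30000 nM (expected range 12000 nM to 75000 nM).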

Compound 4, half-maximal inhibitory concentration: > 100000 nM
Compound 4 ended at the assay's limit; the forecaster's own chance of this, stated with the estimate: 5%; at least 3.3-fold (0.52 log units) between middle value and limit.
By their numbers in this assay, from the lowest: compound 2; then compounds 3 and 1 (each within the scatter of the next). At a limit, above all of these: compound 4.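

In this assay, compound 4 gives > 100000 nM, which is a limit and not a number. Here, placing 3,4-dichlorophenyl in place of 3-ethynylphenyl gives an at least 1.3-fold higher number from compound 1 to compound 4 (0.12 log units; that floor lies within the scatter), so this step alone does not separate the pair beyond the scatter. Even so, the exchange does not carry over between the two cores: the same change on two cores in this assay, a 2.5-fold higher number (0.40 log units; beyond the scatter) from compound 2 to compound 3 and an at least 1.3-fold lower number (0.12 log units; that floor lies within the scatter) from compound 4 to compound 1, at least 3.3-fold (0.52 log units) apart, beyond the scatter of two such steps

From the compounds shown here alone, how much higher a true value for compound 4 would lie remains open. So does whether an amine or a carboxylic acid in place of either group on that nitrogen would lower the number on this core.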